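The compounds below may be only part of what the source reports. "The series", "measured", "known", "first", "only" and "open" are said of these compounds alone.

Working notes on the series.

Three compounds have numbers in an ADME assay on RAW264.7 cells (Mus musculus) for cytotoxicity, read by WST assay (a lower number here means that less compound is tolerated, a higher number that more compound is tolerated), so far. Compound 1 `CC(C)(C)OC(=O)N(Cc1ccco1)C(=O)c1ccc(CN2Cc3ccccc3C2=O)cc1` gives 95200 nM in this assay. Compound 2 `O=C(c1ccc(CN2C(=O)c3ccccc3C2=O)cc1)N1CCCCC1` reaches only a limit of this assay, > 100000 nM. Compound 3 `CC(C)(C)OC(=O)N(Cc1ccco1)C(=O)c1ccc(CN2C(=O)c3ccccc3C2=O)cc1` likewise reaches only a limit of this assay, > 100000 nM, so its standing among the three is known only as a limit, as summarised in the limit of > 100000 nM in this assay, at which 2 of the 3 values shown sit. Within the data shown here, the one measured step that touches compound 3, an at least 1.0-fold higher number from compound 1 to compound 3 (0.02 log units; that floor lies within the scatter), is itself only a floor, and that floor lies within the scatter.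

Compound 4 `O=C(NCc1ccco1)c1ccc(CN2C(=O)c3ccccc3C2=O)cc1` differs from compound 3 by hydrogen in place of tert-butoxycarbonyl on an amide-type nitrogen. Among the measured compounds shown here, no measured step in this assay removes this group, so the only guide is that compound 3 and compound 2 both sit at the limit, and the step from compound 1 to compound 3 stays within the scatter. On that basis a step of about a number no higher from compound 3 to compound 4 (the limit leaves the size open) is expected, that is none beyond the scatter, and compound 4 is estimated at 100000 nM in this assay, with a range from 40000 nM to 300000 nM, most likely reported again as a limit.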

Compound 4, concentration lethal to 50% of the cells: > 100000 nM
Compound 4 ended at the assay's limit; the forecaster's own chance of this, stated with the estimate: 70%; the middle value sits exactly at the limit.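

No new step can be read from compound 2 or compound 3 to compound 4, because all three stand at the same limit: the limit of > 100000 nM in this assay, at which 3 of the 4 values shown sit.

The compounds shown leave open how much of compound 2, compound 3 or compound 4 is tolerated beyond that limit in this assay, and so whether hydrogen in place of tert-butoxycarbonyl changes the read-out.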